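Hydrogen in place of trifluoromethyl in compound 3

The source may hold more compounds than are shown below. What is called first, only, known or untested is meant among the compounds shown, and "the series" means these compounds.

compound 1 `O=C(CCCCC(S)CCS)Nc1ccccc1` gives 8.37%
compound 2 `O=C(CCCCC(S)CCS)Nc1ccc(F)cc1` gives 18.1%
compound 3 `O=C(CCCCC(S)CCS)Nc1ccc([N+](=O)[O-])c(C(F)(F)F)c1` gives 0.97%

In a functional assay on NCI-H460 cells (Homo sapiens) for inhibition, read by MTT assay, with a stated time of 24 h, tested at 10 ug/mL (a lower number here means less inhibition of growth, a higher number more inhibition of growth at the concentration tested), compound 3 at 0.97% sits within the scatter of compound 1 and beyond the scatter under compound 2 on this scale. Compound 4 `O=C(CCCCC(S)CCS)Nc1ccc([N+](=O)[O-])cc1` carries hydrogen in place of trifluoromethyl on an aromatic carbon and keeps the nitro group. Among the measured compounds shown here, the only measured step of a number 9.7 percentage points higher from compound 1 to compound 2 (within the scatter) is a different change, fluoro in place of hydrogen, and it stays within the scatter. No step beyond the scatter is therefore expected in this assay for this change. The estimated step is a number 5 percentage points higher from compound 3 to compound 4 (within the scatter) and it is expected to stay within the scatter. For compound 4 the estimate is 6% with an expected range from 0% to 16% in this read-out.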

Compound 4, percent growth inhibition at one concentration: 13.4%
Compound 4: the middle estimate sits 7.4 percentage points below what was measured; the range from low to high includes it.
By their numbers in this assay, from the lowest: compounds 3, 1, 4 and 2 (each within the scatter of the next, the first and the last beyond it).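

In this assay, hydrogen in place of trifluoromethyl on this aromatic carbon, with the nitro group kept, gives a number 12.4 percentage points higher from compound 3 to compound 4 (beyond the scatter) and so shows that this position can register a change beyond the scatter, though only a modest one. Nitro in place of hydrogen gives a number 5 percentage points higher from compound 1 to compound 4 (within the scatter) and nitro in place of fluoro gives a number 4.7 percentage points lower from compound 2 to compound 4 (within the scatter) and both stay within the scatter, so compound 4 is not separated from compound 1 or compound 2. Nothing available explains the step from trifluoromethyl to hydrogen.

As far as these compounds go, whether a chlorine atom, a methyl group or a nitrile on this carbon would read like hydrogen or like trifluoromethyl remains open. Also open, from the compounds shown here alone, is whether the step would hold without the nitro group.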